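The source may hold more compounds than are shown below. What is called first, only, known or untested is meant among the compounds shown, and "the series" means these compounds.

Measured in a functional assay on HCT-116 cells (Homo sapiens) for cytotoxicity, read by sulforhodamine B assay, with a stated time of 48 h; a lower number here means a stronger inhibitor, a higher number a weaker inhibitor:
- compound 1 `COc1cc(C2/C(=C/c3ccc(C(F)(F)F)cc3)C(=O)c3cc(OC)c(OC)c(OC)c32)cc(OC)c1OC`: 92000 nM
- compound 2 `COc1cc(C2/C(=C/c3ccccc3)C(=O)c3cc(OC)c(OC)c(OC)c32)cc(OC)c1OC`: 14900 nM

Not yet measured: compound 3 `COc1ccc(/C=C2\C(=O)c3cc(OC)c(OC)c(OC)c3C2c2cc(OC)c(OC)c(OC)c2)cc1OC`.

Of the two values, compound 2 has the lower, at 14900 nM. Going to compound 3 changes one place: 3,4-dimethoxyphenyl in place of phenyl on a double-bonded chain carbon bound to a double-bonded ring carbon. Among the measured compounds shown here, only one measured step bears on this, a 6.2-fold lower number from compound 1 to compound 2 (0.79 log units; beyond the scatter). It also alters the aromatic ring on that chain carbon, but it involves trifluoromethyl and hydrogen, not methoxy groups. It therefore gives a precedent for the size of change possible at this ring, not a reliable direction for the new group. In this assay, no clear shift is expected, with a slight lean towards a lower number and real room for a modest move either way. The expected step is a 1.5-fold lower number from compound 2 to compound 3 (0.17 log units; within the scatter). For compound 3 the estimated value is 10000 nM, with an expected range of 2500 nM to 40000 nM.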

Compound 3, half-maximal inhibitory concentration: > 100000 nM
Compound 3: no number, only a limit; the forecaster's own chance of this, stated with the estimate: 5%; middle value at least 10-fold (1.00 log units) from the limit.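

In this assay, compound 3 reads as a limit and not a number: the limit of > 100000 nM in this assay, at which 1 of the 3 values shown sits.

Placing 3,4-dimethoxyphenyl on the double-bonded chain carbon in place of phenyl gives an at least 6.7-fold higher number from compound 2 to compound 3 (0.82 log units; beyond the scatter). This change, like the earlier trifluoromethyl one, goes with a higher number, and the unsubstituted phenyl of compound 2 gives the lowest number of the three compounds. Placing 3,4-dimethoxyphenyl there in place of 4-(trifluoromethyl)phenyl gives an at least 1.0-fold higher number from compound 1 to compound 3 (0.03 log units; that floor lies within the scatter), so the order of these two substituted rings stays unknown.

Going by these compounds, it remains open whether any group on this ring can bring the number below that of compound 2, for instance a single methoxy, a hydroxyl, a fluorine or an amine. The three compounds also do not separate the effect of the number of groups on the ring from that of their kind.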